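The source may hold more compounds than are shown below. What is called first, only, known or untested is meant among the compounds shown, and "the series" means these compounds.

Compound 2 `Oc1ccc(-c2cc(-c3ccco3)nc(-c3ccccc3Cl)c2)cc1` is one of three related compounds examined in a functional assay on DU-145 cells (Homo sapiens) for cytotoxicity, read by CCK-8 assay and cell counting, with a stated time of 2 days; a higher number here means a weaker inhibitor, a lower number a stronger inhibitor. Compound 2 gives 5300 nM, the highest of the two numbers recorded; its nearest neighbour, compound 1 `Oc1ccc(-c2cc(-c3ccccc3)nc(-c3ccccc3Cl)c2)cc1`, gives 2800 nM. For the measured compounds named here, the only step measured so far, a 1.9-fold higher number from compound 1 to compound 2 (0.28 log units; within the scatter), replaces phenyl with furan-2-yl on an aromatic carbon of the shared core. Compound 3 `Oc1ccc(-c2cc(-c3cccnc3)nc(-c3ccccc3Cl)c2)cc1` carries a pyridine ring in that same place, and in this assay compound 3 gives "not determined" (no result reported), so no number is available for it.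

Compound 4 `Oc1ccc(-c2cc(-c3cccc(Cl)c3)nc(-c3ccco3)c2)cc1` differs from compound 2 by 3-chlorophenyl in place of 2-chlorophenyl on an aromatic carbon. Going by the values given here, no measured step concerns the position of the chlorine on the chlorophenyl group, so there is nothing to suggest a change in either direction; the one step recorded lies within the scatter. The expectation for a 1.1-fold lower number from compound 2 to compound 4 (0.03 log units; within the scatter) is therefore no movement beyond the scatter. Compound 4 is estimated at 5000 nM in this assay, with a range from 2000 nM to 13000 nM.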

Compound 4, half-maximal inhibitory concentration: 5750 nM
The estimate for compound 4 lay 1.2-fold (0.06 log units) below the measured number; the range from low to high includes it.
By their numbers in this assay, from the lowest: compounds 1, 2 and 4 (each within the scatter of the next, the first and the last beyond it).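

In this assay, moving the chlorine from 2-chlorophenyl to 3-chlorophenyl, on the aromatic carbon next to the ring nitrogen, gives a 1.1-fold higher number from compound 2 to compound 4 (0.04 log units; within the scatter). For the compounds shown here, the two compounds therefore cannot be told apart here, and this is the first sign that the chlorine's place on this ring need not show up in the result, since the earlier step concerned only furan-2-yl in place of phenyl. No measurement is available to explain this result.

From the compounds shown here alone, only these two chlorine placements on this ring can be compared, so it remains open whether an amine or a carboxylic acid in place of the chlorine would give a number beyond the scatter. The same question stands for a methoxy group in place of the hydroxyl on the 4-hydroxyphenyl group.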